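Moving the chlorine on the chlorophenyl group of compound 3

This account rests on a few compounds, and the source may have more. Where it says the series, first, only, none or still open, it means among the compounds named here.

Of the compounds shown here, three sharing one core have been tested in a functional assay on DU-145 cells (Homo sapiens) for cytotoxicity, read by CCK-8 assay and cell counting, with a stated time of 2 days; a lower number here means a stronger inhibitor, a higher number a weaker inhibitor. Compound 1 `Oc1cccc(-c2cc(-c3ccc(Cl)cc3)nc(-c3cccs3)c2)c1` gives 11600 nM, compound 2 `Oc1ccc(-c2cc(-c3ccc(Cl)cc3)nc(-c3ccccn3)c2)cc1` gives 22500 nM, and compound 3 `Oc1ccc(-c2cc(-c3cccc(Cl)c3)nc(-c3cccs3)c2)cc1` gives 5740 nM. Compound 3 therefore stands lowest of the three, with compound 1 nearest and compound 2 furthest, both beyond the scatter. Compound 4 `Oc1ccc(-c2cc(-c3ccc(Cl)cc3)nc(-c3cccs3)c2)cc1` has not yet been measured in this assay. It is built from the same atoms as compound 3, joined differently: 4-chlorophenyl in place of 3-chlorophenyl on an aromatic carbon. Within the data shown here, no measured pair shows what this change does, so only a small step is expected, most likely none beyond the scatter. Compound 4 is accordingly estimated at 8000 nM in this assay, in the range 3000 nM to 20000 nM, which means an expected step of a 1.4-fold higher number from compound 3 to compound 4 (0.14 log units; within the scatter).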

Compound 4, half-maximal inhibitory concentration: 7660 nM
Compound 4: the middle estimate sits 1.0-fold (0.02 log units) above what was measured, and the stated range covers the measured number.
By their numbers in this assay, from the lowest: compounds 3, 4, 1 and 2 (each within the scatter of the next, the first and the last beyond it).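

In this assay, the step of a 1.3-fold higher number from compound 3 to compound 4 (0.13 log units; within the scatter) shows that this position does not separate 3-chlorophenyl from 4-chlorophenyl. The step of a 1.5-fold lower number from compound 1 to compound 4 (0.18 log units; within the scatter) likewise leaves 3-hydroxyphenyl and 4-hydroxyphenyl unseparated, whereas the step of a 2.9-fold lower number from compound 2 to compound 4 (0.47 log units; beyond the scatter) is the only one of these beyond the scatter, with thiophen-2-yl in place of pyridin-2-yl. No available evidence accounts for these steps. The compounds shown leave open how an amine or a carboxylic acid in place of the chlorine would read in this assay and whether a furan-2-yl group would match thiophen-2-yl.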